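Compound 3 to compound 4: hydroxycarbamoyl given up

This account rests on a few compounds, and the source may have more. Where it says the series, first, only, none or still open, it means among the compounds named here.

In a functional assay on MDA-MB-231 cells (Homo sapiens) for inhibition, read by MTT assay, with a stated time of 72 h (a higher number here means a weaker inhibitor, a lower number a stronger inhibitor), compound 1 `Nc1nc2cc(-c3nn(CCC(=O)NO)c4ncnc(N)c34)ccc2o1` gives > 50000 nM as a limit of the assay and not a number. Within the data shown here, compound 3 `Nc1nc2cc(-c3nn(CCCCCC(=O)NO)c4ncnc(N)c34)ccc2o1` gives 19000 nM and compound 2 `Nc1ncnc2c1c(-c1cnc3[nH]ccc3c1)nn2CCCCCCC(=O)NO` gives 37700 nM here, two values within the scatter of each other and the only actual numbers in the set.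

Compound 4 `CNC(=O)CCCCCCCn1nc(-c2ccc3oc(N)nc3c2)c2c(N)ncnc21` is defined by 2-(methylcarbamoyl)ethyl in place of hydroxycarbamoyl on a saturated chain carbon, five bonds along the chain from an aromatic nitrogen. Among the measured compounds shown here, the single measured step, an at least 2.6-fold lower number from compound 1 to compound 3 (0.42 log units; beyond the scatter), changes the chain and keeps hydroxycarbamoyl. It therefore bears only on the chain part of this change. For the measured compounds named here, no measured compound lacks hydroxycarbamoyl, so the loss of that group is untested and the expectation is loosely grounded.

The ceiling to keep in view is the limit of > 50000 nM in this assay, at which 1 of the 3 values shown sits, for this series. The expected change is a 2.4-fold higher number from compound 3 to compound 4 (0.37 log units; beyond the scatter) in this assay, towards a higher number, with a report at the limit quite possible. For compound 4 the estimated value is 45000 nM with an expected range from 18000 nM to 110000 nM in this assay.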

Compound 4, half-maximal inhibitory concentration: 2900 nM
For compound 4 the middle estimate is 16-fold (1.19 log units) above the measured one, and the stated range ends above it.
By their numbers in this assay, from the lowest: compound 4; then compounds 3 and 2 (each within the scatter of the next). At a limit, above all of these: compound 1.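

In this assay, hydroxycarbamoyl is not needed for a measurable read-out in this series: placing 2-(methylcarbamoyl)ethyl on a saturated chain carbon, five bonds along the chain from an aromatic nitrogen, gives a 6.6-fold lower number from compound 3 to compound 4 (0.82 log units; beyond the scatter). The wider change, 5-(methylcarbamoyl)pentyl in place of hydroxycarbamoyl on a saturated chain carbon, two bonds along the chain from an aromatic nitrogen, gives an at least 17-fold lower number from compound 1 to compound 4 (1.23 log units; beyond the scatter). Compound 1 is a limit of the assay and not a number, so this step is a bound only: the limit of > 50000 nM in this assay, at which 1 of the 4 values shown sits.

Compound 4 alters chain length and end group together, so the share of each in the step stays unresolved; a methylcarbamoyl end on the chain of compound 3 would separate them. Going by these compounds, a carboxylic acid or a primary amide at the chain end, or a longer chain, also remains open.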